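The compounds below may be only part of what the source reports. "The series", "measured", "known", "first", "only" and "open" are said of these compounds alone.

Measured in a functional assay on MIA PaCa-2 cells (Homo sapiens) for inhibition, read by MTT assay, with a stated time of 48 h, tested at 10 uM; a higher number here means more inhibition of growth at the concentration tested, a lower number less inhibition of growth:
compound 1 `Cc1cc(=O)c2c(O)cc(OCc3ccccc3)c([C@H]3CCN(C)C[C@H]3O)c2o1`: 14%
compound 2 `COc1ccc(COc2cc(O)c3c(=O)cc(C)oc3c2[C@H]2CCN(C)C[C@H]2O)cc1`: 15%
compound 3 `Cc1cc(=O)c2c(O)cc(OCc3ccc([N+](=O)[O-])cc3)c([C@H]3CCN(C)C[C@H]3O)c2o1`: 12%

Compound 3, at 12%, lies within the scatter of both other compounds. Compound 4 `Cc1cc(=O)c2c(O)cc(OCc3ccccc3Br)c([C@H]3CCN(C)C[C@H]3O)c2o1` is the next to consider, and the change is 2-bromophenyl in place of 4-nitrophenyl on a saturated chain carbon bound to an oxygen on an aromatic ring. The closest evidence comes from substituent swaps on the same aromatic ring: a number 1 percentage points higher from compound 1 to compound 2 (within the scatter), a number 2 percentage points lower from compound 1 to compound 3 (within the scatter) and a number 3 percentage points lower from compound 2 to compound 3 (within the scatter). Among the measured compounds shown here, all three are small, although no measured compound carries 2-bromophenyl, so this evidence is indirect. The estimate is a number 4 percentage points higher from compound 3 to compound 4 (within the scatter), which means no step beyond the scatter is expected in this assay. For compound 4 the expected value is 16%, with an estimated range from 7% to 32%.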

Compound 4, percent growth inhibition at one concentration: 30%
Estimate against measurement, compound 4: 14 percentage points below; low and high end bracket the measured number.
By their numbers in this assay, from the lowest: compounds 3, 1 and 2 (each within the scatter of the next); then compound 4.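

In this assay, the ring on the saturated chain carbon bound to an oxygen on an aromatic ring now responds to substitution: bromo in place of hydrogen gives a number 16 percentage points higher from compound 1 to compound 4 (beyond the scatter). 2-bromophenyl also stands apart from 4-methoxyphenyl, with a number 15 percentage points higher from compound 2 to compound 4 (beyond the scatter), and from 4-nitrophenyl, with a number 18 percentage points higher from compound 3 to compound 4 (beyond the scatter), so these steps exceed the scatter, unlike the earlier swaps. Nothing available explains this step.

The compounds shown do not separate the effect of bromine from that of its ring position. From the compounds shown here alone, whether 4-bromophenyl, 2-chlorophenyl or 2-aminophenyl would match compound 4 remains open.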